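Adding a Methyl to Compound 3

The source may hold more compounds than are shown below. What is called first, only, known or untested is meant among the compounds shown, and "the series" means these compounds.

Of the compounds shown here, three sharing one core have been tested in an ADME assay on MT4 cells (Homo sapiens) for cytotoxicity, read by MTT assay, with a stated time of 4 days; a lower number here means that less compound is tolerated, a higher number that more compound is tolerated. Compound 1 `Cc1c(Cc2c(F)cccc2F)nc(N(C)C2CCCCC2)[nH]c1=O` gives > 72000 nM, which is a limit. Compound 2 `Cc1c(Cc2c(F)cccc2F)nc(N2CCCCC2C)[nH]c1=O` gives a number, 75000 nM. Compound 3 `Cc1c(Cc2c(F)cccc2F)nc(N2CCCC(C)C2)[nH]c1=O` gives > 75000 nM, which is also a limit, so its position is not fixed by a number.

Compound 4 `Cc1c(C(C)c2c(F)cccc2F)nc(N2CCCC(C)C2)[nH]c1=O` arises from compound 3 through one change, (methyl in place of hydrogen on a saturated chain carbon bound to two aromatic carbons), with methyl in place of hydrogen on a saturated chain carbon bound to two aromatic carbons. Among the compounds with values here, no measured step touches that carbon. The three that exist all alter the group on an aromatic carbon: a step that the limit leaves unreadable from compound 1 to compound 2, a step that the two limits leave unreadable from compound 1 to compound 3 and a number no lower from compound 2 to compound 3 (the limit leaves the size open). None has a readable size, so they offer only indirect guidance. Within the data shown here, the one numerical anchor is compound 2 at 75000 nM, and the expectation rests on it. The expected change is an at least 1.0-fold lower number from compound 3 to compound 4 (0.02 log units; that floor lies within the scatter), with no shift beyond the scatter anticipated, and another limit would be no surprise. For compound 4 the estimated value is 70000 nM, with an expected range from 30000 nM to 120000 nM.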

Compound 4, half-maximal cytotoxic concentration: > 72000 nM
Compound 4: only a limit was reported; the forecaster's own chance of this, stated with the estimate: 45%; middle value at least 1.0-fold (0.01 log units) away from the limit.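

In this assay compound 4 gives > 72000 nM, which is a limit. Compound 3 also stands at a limit, so the step between these two compounds cannot be read. The compounds shown leave open whether methyl in place of hydrogen on this saturated chain carbon changes the number at all.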